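Fluoro in place of chloro, following compound 1

This account rests on a few compounds, and the source may have more. Where it says the series, first, only, none or still open, it means among the compounds named here.

Compound 1 `CSc1nnc(Cc2ccc(Cl)cc2Oc2ccccc2Cl)[nH]1` gives 125% in a functional assay on the whole organism (strain NMRI) with Mus musculus as the target, with a stated time of 60 min, at a dose of 5 mg/kg by the intraperitoneal route; on this read-out higher numbers stand for a stronger effect at the one dose given and lower numbers for a weaker effect. Within the data shown here, compound 2 `CCCSc1nnc(Cc2ccc(Cl)cc2Oc2ccccc2Cl)[nH]1` gives 118%; the one step in hand, a number 7 percentage points lower from compound 1 to compound 2 (within the scatter), alters the chain on the sulfur and leaves the two compounds within the scatter of each other. Compound 3 `CSc1nnc(Cc2ccc(Cl)cc2Oc2ccccc2F)[nH]1` carries a single change from compound 1: fluoro in place of chloro on an aromatic carbon. Among the measured compounds shown here, no measured step touches this aromatic carbon, so nothing in hand bears directly on the change. A step no larger than the scatter is therefore expected, a number 5 percentage points lower from compound 1 to compound 3 (within the scatter). Compound 3 is estimated at 120%, within 95% to 145%.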

Compound 3, a percentage reported as activity, at one dose (the size of the read-out at that dose, not a potency): 110%
Compound 3: the middle estimate sits 10 percentage points above what was measured, within the range that was stated.
By their numbers in this assay, from the lowest: compounds 3, 2 and 1 (each within the scatter of the next, the first and the last beyond it).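

Replacing 2-chlorophenyl with 2-fluorophenyl gives a number 15 percentage points lower from compound 1 to compound 3 (beyond the scatter) in this assay, a modest step, which makes this aromatic carbon the first place in the series where a single change goes beyond the scatter. Compound 3 still gives 110%, so the effect at the one dose is lowered, not lost. No measurement in hand accounts for the step.

Open, from the compounds shown here alone, is how methyl, methoxy or plain hydrogen on this aromatic carbon would compare with chloro and fluoro. Also open, going by these compounds, is whether the same step appears with the longer sulfur chain of compound 2.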